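Aryl swap on the amino acid series, compound 4 outlook

The source may report more compounds than this note shows. Statements on the series, on what has been measured and on what is new or still open speak of the compounds shown alone.

Compound 1 `CCCN(Cc1ccc(OCCn2c(=O)ccn(C)c2=O)c(OC)c1)C(CC(=O)O)c1ccc(Cl)cc1` gives 132 nM in an assay on CHO cells for displacement of a labelled ligand from C-X-C chemokine receptor type 3 (Homo sapiens), with a stated time of 60 min; on this read-out lower numbers stand for stronger inhibition and higher numbers for weaker inhibition.
Compound 2 `CCCN(Cc1ccc(OCCn2c(=O)ccn(C)c2=O)c(OC)c1)C(CC(=O)O)c1ccc2c(c1)CCO2` gives 154 nM in this assay.
Compound 3 `COc1cc(CN(CC(C)C)C(CC(=O)O)c2ccc3c(c2)CCO3)ccc1OCCN1C(=O)CCC1=O` gives 41 nM in this assay.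

Compound 2 and compound 1 differ in one place: a group of 7 heavy atoms (6 carbon, 1 chlorine; one six-membered aromatic ring of carbon only) in place of a group of 9 heavy atoms (8 carbon, 1 oxygen; one five-membered non-aromatic ring with 1 hetero atom, one six-membered aromatic ring of carbon only), on a saturated chain carbon bound to an amine nitrogen and a saturated chain carbon. This change gives a 1.2-fold lower number from compound 2 to compound 1 (0.07 log units; within the scatter). Compound 3 differs from compound 2 in more than this group; the difference between the two cores is not broken down here. In this assay compound 3 stands lowest of the three measured compounds, its steps to compound 1 and to compound 2 both lying beyond the scatter.

Compound 4 `COc1cc(CN(CC(C)C)C(CC(=O)O)c2ccc(Cl)cc2)ccc1OCCN1C(=O)CCC1=O` is not yet measured. It carries the same change on the core of compound 3: a group of 7 heavy atoms (6 carbon, 1 chlorine; one six-membered aromatic ring of carbon only) in place of a group of 9 heavy atoms (8 carbon, 1 oxygen; one five-membered non-aromatic ring with 1 hetero atom, one six-membered aromatic ring of carbon only), on a saturated chain carbon bound to an amine nitrogen and a saturated chain carbon. Going by the values given here, the one measured reading of this change, from compound 2 to compound 1, lies within the scatter, so compound 4 is expected to sit close to compound 3 in this assay, with a 1.1-fold lower number from compound 3 to compound 4 (0.06 log units; within the scatter) as the expected step, resting on a 1.2-fold lower number from compound 2 to compound 1 (0.07 log units; within the scatter). The estimate for compound 4 is 36 nM, with an expected range from 15 nM to 90 nM.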

Compound 4, half-maximal inhibitory concentration in the C-X-C chemokine receptor type 3 assay: 34 nM
The estimate for compound 4 lay 1.1-fold (0.02 log units) above the measured number; low and high end bracket the measured number.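

In the C-X-C chemokine receptor type 3 assay compound 4 gives 34 nM. In the C-X-C chemokine receptor type 3 assay, 4-chlorophenyl entering on the core of compound 3 gives a 1.2-fold lower number from compound 3 to compound 4 (0.08 log units; within the scatter), and the two readings of this change lie within the scatter of each other: the same change on two cores in the C-X-C chemokine receptor type 3 assay, a 1.2-fold lower number (0.07 log units; within the scatter) from compound 2 to compound 1 and a 1.2-fold lower number (0.08 log units; within the scatter) from compound 3 to compound 4, 1.0-fold (0.01 log units) apart, within the scatter of two such steps
On these two cores, then, the change carries over with no step beyond the scatter, so the two groups are interchangeable in this read-out for these pairs; this rests on two pairs only and does not show the same for other cores in the series. In a physicochemical assay for solubility, at pH 1.1 (on this read-out lower numbers stand for lower solubility and higher numbers for higher solubility), compound 3 gives 3000000 nM and compound 4 gives 3000000 nM. In the physicochemical assay the same change gives no change at the digits printed from compound 3 to compound 4 (within the scatter), but this is a single pair, so it shows nothing about carrying the change from one core to another in that read-out.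

The compounds shown do not break down the difference between the two cores, so it remains open which part of it goes with the number of compound 3. Also open, from the compounds shown here alone, is how other groups in the same place, such as 4-fluorophenyl or unsubstituted phenyl, would read in either assay.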